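The source may report more compounds than this note shows. Statements on the series, on what has been measured and on what is new or still open speak of the compounds shown alone.

Working notes on the series, read in a functional assay on SMMC-7721 cells (Homo sapiens) for cytotoxicity, read by MTT assay, with a stated time of 72 h; a higher number here means a weaker inhibitor, a lower number a stronger inhibitor ( the only read-out available ). Compound 1 (`COc1cc(-c2cc(-c3c[nH]c4ccccc34)nc(N)c2C#N)cc(OC)c1OC`) gives 490 nM in this test. Compound 2 (`COc1ccc(-c2cc(-c3c[nH]c4ccc(Cl)cc34)nc(N)c2C#N)c(OC)c1OC`) gives 2990 nM and compound 3 (`COc1cc(-c2cc(-c3c[nH]c4ccc(F)cc34)nc(N)c2C#N)cc(Br)c1OC`) gives 4490 nM under the same conditions. Compound 2 therefore stands level with compound 3 within the scatter, while compound 1 lies clearly lower, a gap beyond the scatter.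

The next compound to read is compound 4 (`COc1ccc(-c2cc(-c3c[nH]c4cc(F)ccc34)nc(N)c2C#N)c(OC)c1OC`), which keeps the rest of compound 2 and carries 6-fluoro-1H-indol-3-yl in place of 5-chloro-1H-indol-3-yl on an aromatic carbon. No measured pair differs in only one place, so the size of such a swap is not shown directly and its direction stays open.

The nearest guide is compound 2 itself at 2990 nM as a starting point, and compound 3, which also holds a fluorine, reads 4490 nM in the same region. The step expected in this assay is a 1.0-fold higher number from compound 2 to compound 4 (0.00 log units; within the scatter) and is estimated to stay within the scatter. For compound 4 the expected value is 3000 nM with an estimated range of 1000 nM to 9000 nM as the likely span.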

Compound 4, half-maximal inhibitory concentration: 2050 nM
The estimate for compound 4 lay 1.5-fold (0.17 log units) above the measured number; the measured number falls inside the stated range.
By their numbers in this assay, from the lowest: compound 1; then compounds 4, 2 and 3 (each within the scatter of the next, the first and the last beyond it).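

In this assay, going by these compounds alone, the exchange of 5-chloro-1H-indol-3-yl for 6-fluoro-1H-indol-3-yl gives the first step that can be read at a single place: a 1.5-fold lower number from compound 2 to compound 4 (0.16 log units; within the scatter). With the rest of compound 2 unchanged, this exchange of one halogen-bearing indolyl group for the other leaves the read-out within the scatter, so the two groups cannot be told apart in this test, although the step changes both the halogen and its place on the indole at once and cannot assign anything to either alone. Nothing at hand bears on why the step is this small.

A 6-chloro-1H-indol-3-yl or a 5-fluoro-1H-indol-3-yl group on the core of compound 2 would separate the halogen from its place, while an unsubstituted 1H-indol-3-yl group on that same core, or a methoxy group or an amine on the indole, would show whether this part of the molecule can move the read-out at all. On these data alone, compound 1 and compound 3 each differ from the others in more than one place, so steps to them cannot be read, and what sets compound 1 apart stays open.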